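From cyclopropylmethyl to 1-carboxyethyl: compound 2 to compound 4

This account rests on a few compounds, and the source may have more. Where it says the series, first, only, none or still open, it means among the compounds named here.

In an ADME assay on a cell-free system (plasma, Homo sapiens) (on this read-out higher numbers stand for a larger free fraction and lower numbers for a smaller free fraction), compound 2 (`CCNC(=O)Nc1nc2cc(-c3cccnc3)c(=O)n(CC3CC3)c2s1`) gives 0.05, the lower of the two numbers available. Compound 3 (`CCNC(=O)Nc1nc2cc(-c3cccnc3)c(=O)n(CC3CCOCC3)c2s1`) gives 0.14, and compound 1 (`CCNC(=O)Nc1nc2cc(-c3ccc(F)nc3)c(=O)n(C)c2s1`) stands as "not determined" (no result reported). Compound 4 (`CCNC(=O)Nc1nc2cc(-c3cccnc3)c(=O)n(C(C)C(=O)O)c2s1`) has 1-carboxyethyl in place of cyclopropylmethyl on an aromatic nitrogen. Among the measured compounds shown here, no measured compound carries 1-carboxyethyl, so only one measured step bears on this change. With oxan-4-yl in place of cyclopropyl, that step is modest and beyond the scatter: a 2.8-fold higher number from compound 2 to compound 3 (0.45 log units; beyond the scatter). A modest rise in this assay is expected, with low confidence, as a 2.2-fold higher number from compound 2 to compound 4 (0.34 log units; beyond the scatter). The estimate for compound 4 is 0.11, with an expected range of 0.04 to 0.3.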

Compound 4, unbound fraction: 0.22
Compound 4: the middle estimate sits 2.0-fold (0.30 log units) below what was measured; the range from low to high includes it.
By their numbers in this assay, from the lowest: compound 2; then compounds 3 and 4 (each within the scatter of the next).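

In this assay 1-carboxyethyl in place of cyclopropylmethyl on the aromatic nitrogen gives a 4.4-fold higher number from compound 2 to compound 4 (0.64 log units; beyond the scatter) and shows that a group with no ring can also raise this read-out at this position. Against (oxan-4-yl)methyl, 1-carboxyethyl gives a 1.6-fold higher number from compound 3 to compound 4 (0.20 log units; within the scatter) and is therefore not separated from it here. Open, as far as these compounds go, is whether the carboxyl group alone accounts for the step from cyclopropylmethyl, and what a methyl ester, a primary amide or an amine would give on this nitrogen. No measurement at hand explains either step.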